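Opening the Side Chain of Compound 2

A few compounds are considered here, and "the series" means these few. Any claim that something is new, unique, unknown or untested is made for them only; others in the source may bear on it.

For the measured compounds named here, in a functional assay on G-361 cells (Homo sapiens) for cytotoxicity, read by fluorescence, with a stated time of 72 h (on this read-out higher numbers stand for weaker inhibition and lower numbers for stronger inhibition), compound 1 `CC(C)c1n[nH]c2c(NCc3ccc(-c4ccccn4)cc3)nc(NCCO)nc12` gives 39 nM and compound 2 `CC(C)c1n[nH]c2c(NCc3ccc(-c4ccccn4)cc3)nc(N3CCCCC3CCO)nc12` gives 204 nM as the higher of the two numbers so far, which makes it the weaker inhibitor of the pair. Compound 3 `CC(C)c1n[nH]c2c(NCc3ccc(-c4ccccn4)cc3)nc(NCCN)nc12` has not yet been measured. It carries (2-aminoethyl)amino in place of 2-(2-hydroxyethyl)piperidin-1-yl on the same aromatic carbon (2-aminoethyl)amino in place of 2-(2-hydroxyethyl)piperidin-1-yl on an aromatic carbon so the ring is gone. Going by the values given here, one measured step bears on this: a 5.2-fold higher number from compound 1 to compound 2 (0.72 log units; beyond the scatter) when 2-(2-hydroxyethyl)piperidin-1-yl took the place of (2-hydroxyethyl)amino. Losing that ring is expected to undo most of this modest step, although no measured step tests an amino group in place of the hydroxyl. The expected change is a modest one toward stronger inhibition, a 4.5-fold lower number from compound 2 to compound 3 (0.66 log units; beyond the scatter) in size. Compound 3 is estimated at 45 nM with 15 nM to 130 nM as the expected range.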

Compound 3, half-maximal inhibitory concentration: 230 nM
The estimate for compound 3 lay 5.1-fold (0.71 log units) below the measured number; the measured number lies above the stated range.
By their numbers in this assay, from the lowest: compound 1; then compounds 2 and 3 (each within the scatter of the next).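

In this assay, removing the ring does not by itself bring back the low number of compound 1: with (2-aminoethyl)amino on the aromatic carbon, the step is a 1.1-fold higher number from compound 2 to compound 3 (0.05 log units; within the scatter) and leaves the two compounds level. With the open chain kept, changing only its end from hydroxy to amino gives a 5.9-fold higher number from compound 1 to compound 3 (0.77 log units; beyond the scatter) and thus a clear loss, so at this position the end of the chain matters as well as the ring, and two quite different changes can lead to similar numbers. Nothing available explains why the amino end behaves this way.

From the compounds shown here alone, it remains open whether the loss belongs to amino groups generally or to this primary amine alone. A methoxy or carboxylic acid at the chain end, or a longer chain carrying a hydroxy group, could help to separate these possibilities.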